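The compounds below may be only part of what the source reports. "The series", "measured", "known", "first", "only" and "open" are said of these compounds alone.

Working notes on the series, read in a functional assay on brain (Rattus norvegicus, strain Wistar) for inhibition; a higher number here means a weaker inhibitor, a lower number a stronger inhibitor. Compound 1 (`CCCCCc1ccc(-c2c(C)[nH]c(=O)n2C)cc1`) gives 5900 nM, and compound 2 (`Cc1[nH]c(=O)n(C)c1-c1ccc(OCCC(C)C)cc1`) gives 6600 nM. Within the data shown here, these are the only two numbers available, and they lie within the scatter of each other, so compound 1 holds no distinct place. Compound 3 (`CCCCCCCCCCCCc1ccc(-c2c(C)[nH]c(=O)n2C)cc1`) keeps the core of compound 1 and differs by heptyl in place of hydrogen on a saturated chain carbon, five bonds along the chain from an aromatic carbon. The added heptyl makes this a much larger change on the chain than isopentyloxy in place of pentyl. Among the measured compounds shown here, the only measured step, a 1.1-fold higher number from compound 1 to compound 2 (0.05 log units; within the scatter), is small, but it bears only loosely on this change. No measured extension of the chain exists, so the direction remains uncertain. A moderate move toward a lower number is expected, with an estimated 2.4-fold lower number from compound 1 to compound 3 (0.37 log units; beyond the scatter). Compound 3 is estimated at 2500 nM, with an expected range of 500 nM to 12000 nM.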

Compound 3, half-maximal inhibitory concentration: 13000 nM
For compound 3 the middle estimate is 5.2-fold (0.72 log units) below the measured one; the measured number lies above the stated range.
By their numbers in this assay, from the lowest: compounds 1, 2 and 3 (each within the scatter of the next, the first and the last beyond it).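

In this assay, heptyl in place of hydrogen on a saturated chain carbon, five bonds along the chain from an aromatic carbon, gives a 2.2-fold higher number from compound 1 to compound 3 (0.34 log units; beyond the scatter). This position therefore responds to chain extension, and here the response is a modest loss of inhibition rather than a gain. Among these compounds, the earlier pair showed no change beyond the scatter, so this is the first step to pass it, although the shift remains modest for so large an addition.

Still open, on these data alone, is whether the number rises steadily with chain length or only once the chain is long, and whether an amine or a carboxylic acid in place of the heptyl would read differently. No evidence at hand bears on the origin of this step.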